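A Thiophene for a Pyrrole on a Level Series

The source may report more compounds than this note shows. Statements on the series, on what has been measured and on what is new or still open speak of the compounds shown alone.

In a functional assay on SK-BR-3 cells (Homo sapiens) for cytotoxicity, read by resazurin assay, with a stated time of 72 h (a higher number here means a weaker inhibitor, a lower number a stronger inhibitor), compound 1 (`S=C(NCc1cccnc1)SCCc1nnc(-c2ccc(Cl)cc2)o1`) gives 860 nM and compound 2 (`O=[N+]([O-])c1ccc(-c2nnc(CCSC(=S)NCc3cccnc3)o2)cc1`) gives 1540 nM while compound 3 (`S=C(NCc1cccnc1)SCCc1nnc(-c2cc[nH]c2)o1`) gives 820 nM on the same scale. Compound 3 thus sits level with the other two: the data show a 1.0-fold lower number from compound 1 to compound 3 (0.02 log units; within the scatter) and a 1.9-fold lower number from compound 2 to compound 3 (0.27 log units; within the scatter) so these three cannot be told apart.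

Compound 4 (`S=C(NCc1cccnc1)SCCc1nnc(-c2cccs2)o1`) has thiophen-2-yl in place of 1H-pyrrol-3-yl on an aromatic carbon of the shared core (thiophen-2-yl in place of 1H-pyrrol-3-yl on an aromatic carbon). Both groups are five-membered aromatic rings, and the hetero atom changes from nitrogen to sulfur.

Among the measured compounds shown here, no measured step trades one five-membered ring for another, so the closest guide is what other changes to the group on that same carbon have done. The two steps to compound 3 swapped the whole group and a 1.8-fold higher number from compound 1 to compound 2 (0.25 log units; within the scatter) changed only a substituent on it, and none of the three left the scatter. With nothing larger seen so far, no step beyond the scatter is expected in this assay and the estimated move is a 1.1-fold higher number from compound 3 to compound 4 (0.04 log units; within the scatter) as a central guess. Compound 4 is therefore estimated at 900 nM with an expected range from 430 nM to 1800 nM in this measurement.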

Compound 4, half-maximal inhibitory concentration: 1070 nM
Beside the measured number, compound 4's estimate is 1.2-fold (0.08 log units) below it, within the range that was stated.
By their numbers in this assay, from the lowest: compounds 3, 1, 4 and 2 (each within the scatter of the next).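

In this assay, among the compounds shown here, this is the first trade of one five-membered aromatic ring for another at this carbon, and a 1.3-fold higher number from compound 3 to compound 4 (0.12 log units; within the scatter) shows that it stays within the scatter, even though thiophen-2-yl has 0 hydrogen-bond donors where 1H-pyrrol-3-yl has 1 and sulfur replaces nitrogen as the hetero atom. The new compound also cannot be told apart from the two compounds that carry a phenyl ring, with a 1.2-fold higher number from compound 1 to compound 4 (0.09 log units; within the scatter) and a 1.4-fold lower number from compound 2 to compound 4 (0.16 log units; within the scatter), so all four aromatic groups at this position give results within the scatter of one another. No measurement is available that would explain this flat result.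

Every group shown on this carbon is an aromatic ring, so what a saturated ring such as cyclohexyl, a small chain such as methyl, or a phenyl ring bearing a carboxylic acid would do remains open. On these data alone, it is also open whether a change elsewhere on the shared core would produce a step beyond the scatter, which no change at this carbon has yet done.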